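Halogen pattern on the aryl ring: compound 3 to 4

The compounds below may be only part of what the source reports. "The series", "measured", "known", "first", "only" and "open" are said of these compounds alone.

Compound 1 `O=C(Nc1ccc(Oc2ccnc3[nH]ccc23)cc1)c1cc2cccnc2n(-c2ccc(F)cc2)c1=O`: 210 nM
Compound 2 `O=C(Nc1ccc(Oc2ccnc3[nH]ccc23)cc1)c1cc2cccnc2n(-c2ccc(Cl)cc2)c1=O`: 290 nM
Compound 3 `O=C(Nc1ccc(Oc2ccnc3[nH]ccc23)cc1)c1cc2cccnc2n(-c2ccc(F)c(Cl)c2)c1=O`: 680 nM

Of the compounds shown here, three sharing one core have been measured in a functional assay on A549 cells (Homo sapiens) for antiproliferative activity, read by MTT assay, with a stated time of 72 h; a lower number here means a stronger inhibitor, a higher number a weaker inhibitor. Compound 3 stands at the highest number of the three; its nearest neighbour is compound 2, and compound 1 lies furthest from it. Compound 4 `O=C(Nc1ccc(Oc2ccnc3[nH]ccc23)cc1)c1cc2cccnc2n(-c2ccc(Br)cc2F)c1=O` carries the change (4-bromo-2-fluorophenyl in place of 3-chloro-4-fluorophenyl on an aromatic nitrogen).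

The measured steps touch this change only in part. Exchanging a single halogen for another gave a 1.4-fold higher number from compound 1 to compound 2 (0.14 log units; within the scatter), adding a second chloro gave a 3.2-fold higher number from compound 1 to compound 3 (0.51 log units; beyond the scatter), and the comparison of the two disubstituted and monosubstituted rings gave a 2.3-fold higher number from compound 2 to compound 3 (0.37 log units; beyond the scatter). Among the measured compounds shown here, no measured step covers a bromo, nor a fluoro placed as in compound 4. What the three compounds show is that two halogens on this ring gave a somewhat higher number than one, while the identity of a single halogen mattered little. Compound 4 keeps two halogens but rearranges them, so compound 4 is expected to land near compound 3 or somewhat lower, with the step of a 1.5-fold lower number from compound 3 to compound 4 (0.18 log units; within the scatter) treated as uncertain. Compound 4 is therefore estimated at 450 nM, within 150 nM to 1400 nM, in this assay.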

Compound 4, half-maximal inhibitory concentration: 1570 nM
For compound 4 the middle estimate is 3.5-fold (0.54 log units) below the measured one, and the stated range ends below it.
By their numbers in this assay, from the lowest: compounds 1 and 2 (each within the scatter of the next); then compound 3; then compound 4.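

In this assay the 4-bromo-2-fluorophenyl ring of compound 4 gives the highest number of the four, with a 2.3-fold higher number from compound 3 to compound 4 (0.36 log units; beyond the scatter) showing that two rings each bearing two halogens do not sit at one level on this aromatic nitrogen. The gap to the rings with one halogen is wider, with a 5.4-fold higher number from compound 2 to compound 4 (0.73 log units; beyond the scatter) and a 7.5-fold higher number from compound 1 to compound 4 (0.87 log units; beyond the scatter) placing compound 4 well above both, so the two rings with two halogens stand at higher numbers than the two with one, and no compound shown goes against that order; the number of halogens alone, however, does not fix the value, since compound 3 and compound 4 differ while both carry two. Nothing available here accounts for the rise in the number.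

Compound 4 differs from compound 3 in both the heavier halogen and the places of its halogens, so the share of each change in the step stays unresolved. Also open, from the compounds shown here alone, is how this position responds to a ring carrying no halogen at all, such as one with a methoxy group or an amine.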